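A few compounds are considered here, and "the series" means these few. Any claim that something is new, unique, unknown or untested is made for them only; others in the source may bear on it.

The measured compounds in a functional assay on HeLa cells (Homo sapiens) for cytotoxicity, read by cell counting, with a stated time of 4 days (on this read-out higher numbers stand for weaker inhibition and lower numbers for stronger inhibition), are:
- compound 1, `Nc1cccc(/C=C2\SC(=O)N(Cc3cccc(F)c3)C2=O)c1`; this value is a limit of the assay, not a number: > 250000 nM
- compound 2, `Nc1ccc(/C=C2\SC(=O)N(Cc3cccc(F)c3)C2=O)cc1`: 250000 nM
- compound 3, `C=C(Br)C(=O)Nc1ccc(/C=C2\SC(=O)N(Cc3cccc(F)c3)C2=O)cc1`: 5900 nM

Compound 2 stands at the highest of the two numbers shown, with compound 3 below it by a 42-fold lower number from compound 2 to compound 3 (1.63 log units; beyond the scatter). The other value, for compound 1, is a limit (the limit of > 250000 nM in this assay, at which 1 of the 3 values shown sits). The step from compound 1 to compound 2 is a number no higher from compound 1 to compound 2 (the limit leaves the size open).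

Compound 4, `CN1C(=O)S/C(=C\c2ccc(N)cc2)C1=O`, differs from compound 2 in one place: hydrogen in place of 3-fluorophenyl on a saturated chain carbon bound to an amide-type nitrogen in a ring. Among the measured compounds shown here, none of the measured steps touches this position. For the measured compounds named here, the one numbered step, from compound 2 to compound 3, changes the nitrogen on the aromatic ring, and the step from compound 1 to compound 2 moves the amino group on the ring; neither speaks to the group on the saturated chain carbon. Compound 2 already sits at the weak end of the numbers shown, so the expectation for compound 4 rests on that alone. The step from compound 2 to compound 4 is expected to be no change at the digits printed from compound 2 to compound 4 (within the scatter), with a real chance that this assay reports only a limit. Compound 4 is estimated at 250000 nM, within 80000 nM to 800000 nM.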

Compound 4, half-maximal inhibitory concentration: 97000 nM
For compound 4 the middle estimate is 2.6-fold (0.41 log units) above the measured one, within the range that was stated.
By their numbers in this assay, from the lowest: compound 3; then compound 4; then compound 2.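

In this assay, among the compounds shown here, this is the first measured change at the saturated chain carbon bound to an amide-type nitrogen in a ring, and it gives a 2.6-fold lower number from compound 2 to compound 4 (0.41 log units; beyond the scatter). Hydrogen in place of 3-fluorophenyl removes an aromatic ring of carbon only, yet the number falls modestly rather than rising, so 3-fluorophenyl is not required for the inhibition that compound 2 shows here. Nothing measured among these compounds explains this shift.

On these data alone, it remains open whether a longer chain or a carboxylic acid at this place would take the number lower still or reverse the shift. As far as these compounds go, it is also open whether hydrogen in place of 3-fluorophenyl would have a similar effect when the (1-bromoethenyl)carbonyl group of compound 3 is present.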